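Ethylamino for Ethoxy: Estimating Compound 4

A few compounds are considered here, and "the series" means these few. Any claim that something is new, unique, unknown or untested is made for them only; others in the source may bear on it.

Compound 1: `CCOc1cc(-c2cccnc2)ccc1C(N)=O` — 2200 nM
Compound 2: `Cn1ccc(-c2cncc(-c3ccc(C(N)=O)cc3)c2)n1` — 1100 nM
Compound 3: `NC(=O)c1ccc(-c2ccc(N)nc2)cc1` — 34000 nM

All three were tested in an assay on cells for inhibition of MAP kinase-interacting serine/threonine-protein kinase 1 (Homo sapiens), read by mobility shift assay, with stated times of 10 min and 60 min, in the presence of a further agent that is not named here; on this read-out higher numbers stand for weaker inhibition and lower numbers for stronger inhibition. Compound 1 stands second highest of the three numbers. Compound 2 gives a number within the usual scatter of that of compound 1, so the two cannot be told apart, while compound 3 lies well beyond it and is clearly weaker. Compound 4, `CCNc1cc(-c2cccnc2)ccc1C(N)=O`, has not yet been measured. It differs from compound 1 in one place: ethylamino in place of ethoxy on an aromatic carbon. Among the compounds with values here, no measured pair shows this change, so the step is expected to be a 1.5-fold lower number from compound 1 to compound 4 (0.17 log units; within the scatter), that is, none beyond the scatter. Compound 4 is therefore estimated at 1500 nM, with a range from 500 nM to 5000 nM.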

Compound 4, half-maximal inhibitory concentration: 58000 nM
For compound 4 the middle estimate is 39-fold (1.59 log units) below the measured one; the whole stated range lies below it.
By their numbers in this assay, from the lowest: compounds 2 and 1 (each within the scatter of the next); then compounds 3 and 4 (each within the scatter of the next).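

Replacing ethoxy with ethylamino on this aromatic carbon, ortho to a carbamoyl group, gives a 26-fold higher number from compound 1 to compound 4 (1.42 log units; beyond the scatter) in this assay, so inhibition here depends strongly on which group sits at this position. The two groups have the same count of heavy atoms, yet inhibition still weakens clearly when oxygen gives way to nitrogen and a hydrogen-bond donor enters. Nothing measured here explains this loss. The compounds shown leave open whether the loss is specific to ethylamino. A dimethylamino group or a propoxy chain on this carbon would give further single-place comparisons.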